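Sulfonamide variation on a benzoxazole core: compound 1 to compound 4

The source may report more compounds than this note shows. Statements on the series, on what has been measured and on what is new or still open speak of the compounds shown alone.

The shared core is carried by compound 1 `C=Cc1ccc(S(=O)(=O)Nc2ccc3oc(-c4ccccc4)nc3c2)cc1`, compound 2 `O=S(=O)(Nc1ccc(-c2nc3ccccc3o2)cc1)c1ccccc1F` and compound 3 `COc1ccccc1S(=O)(=O)Nc1ccc(-c2nc3ccccc3o2)cc1`. In an assay on isolated protein for inhibition of malate dehydrogenase, mitochondrial (Sus scrofa), with stated times of 45 min and 30 min (on this read-out higher numbers stand for weaker inhibition and lower numbers for stronger inhibition), compound 1 gives > 63000 nM, which is a limit of the assay rather than a number. Compound 2 gives > 63000 nM in this assay, again a limit. Compound 3 gives > 63000 nM, also a limit. Within the data shown here, the one measured step, a step that the two limits leave unreadable from compound 2 to compound 3, therefore cannot be read, and all that is known is the limit of > 63000 nM in this assay, at which 3 of the 3 values shown sit.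

Compound 4 `Cc1cccc(S(=O)(=O)Nc2ccc3oc(-c4ccccc4)nc3c2)c1` is the unmeasured partner of compound 1. The change is 3-methylphenyl in place of 4-vinylphenyl on a sulfonyl sulfur. Among the measured compounds shown here, no measured step speaks to this change; the step from compound 2 to compound 3 involves a different ring position and a different pair of groups and is in any case unreadable. With compound 1 sitting at the limit and every measured compound in this assay sitting at the same limit, the expectation for compound 4 is that it remains at or beyond that limit.

Compound 4 is therefore estimated at 100000 nM, within a range of 40000 nM to 300000 nM. The step expected from this estimate is a step that the limit leaves unreadable from compound 1 to compound 4, which most likely will itself be reported only as a limit.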

Compound 4, half-maximal inhibitory concentration: > 63000 nM
Compound 4 ended at the assay's limit; the forecaster's own chance of this, stated with the estimate: 85%; the middle value does not contradict the limit.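

No size can be read for the step between compound 1 and compound 4 because both compounds sit at the assay's limit, as does every other compound shown: the limit of > 63000 nM in this assay, at which 4 of the 4 values shown sit. The compounds shown leave open what structure, if any, would give an actual number in this assay, and how 3-methylphenyl and 4-vinylphenyl truly compare.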